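Compound 4: a hydroxy swap at the assay limit

The source may report more compounds than this note shows. Statements on the series, on what has been measured and on what is new or still open speak of the compounds shown alone.

Values measured in an ADME assay on HepG2 cells (Homo sapiens) for cytotoxicity, read by luminescence, with a stated time of 72 h (a higher number here means that more compound is needed for the effect, a lower number that less compound is needed), for three compounds:
- Compound 1 `CCOC(=O)c1c(-c2cccc(Oc3ccccc3)c2)[nH]c2cc(OC)ccc2c1=O` gives > 21500 nM as a limit of the assay, not a number
- Compound 2 `CCOC(=O)c1c(-c2cccc(Cl)c2)[nH]c2cc(OC)ccc2c1=O` gives > 21500 nM as a limit of the assay, not a number
- Compound 3 `CCOC(=O)c1c(-c2cccc(N(C)C)c2)[nH]c2cc(OC)ccc2c1=O` gives > 21500 nM as a limit of the assay, not a number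

Compound 3 stands at the limit of > 21500 nM in this assay, at which 3 of the 3 values shown sit, and so offers no number to start from. The move to compound 4 `CCOC(=O)c1c(-c2cccc(O)c2)[nH]c2cc(OC)ccc2c1=O` is hydroxy in place of dimethylamino on an aromatic carbon, turning 3-(dimethylamino)phenyl into 3-hydroxyphenyl.

Each of a step that the two limits leave unreadable from compound 1 to compound 3 and a step that the two limits leave unreadable from compound 2 to compound 3 and a step that the two limits leave unreadable from compound 1 to compound 2 swaps a group at this same place on the shared core, and none of them has a readable size. Phenoxy, chloro and dimethylamino all leave their compounds at the one limit, and none of the three goes against that. Hydroxy itself has no measurement yet. A clear step in either direction in this assay is therefore not expected, and the most likely report is again a limit. The expected outcome is a number no higher from compound 3 to compound 4 (the limit leaves the size open) for this swap. For compound 4 the estimated value is 21500 nM, with an expected range from 10000 nM to 30000 nM as a rough estimate.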

Compound 4, half-maximal effective concentration: > 21500 nM
Compound 4: a limit, no number; the forecaster's own chance of this, stated with the estimate: 80%; the middle value lies on the limit itself.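

In this assay compound 4 gives > 21500 nM, a limit of the assay and not a number. No step from compound 1, compound 2 or compound 3 to compound 4 can be read: the limit of > 21500 nM in this assay, at which 4 of the 4 values shown sit.

The compounds shown leave open what concentration of any of these four gives the half-maximal effect, and whether swapping the group at this place on the shared core changes it at all.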